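Aryl swap on the thioether carbon: compound 3 to compound 4

The compounds below may be only part of what the source reports. "The series", "measured", "known", "first", "only" and "open" are said of these compounds alone.

Measured compounds in an assay on isolated protein for inhibition of Retinaldehyde dehydrogenase 3 (Homo sapiens); a higher number here means a weaker inhibitor, a lower number a stronger inhibitor:
- compound 1, `CC(Sc1nc2c(cnn2C)c(=O)n1-c1ccccc1)c1ccccn1`, gives 89 nM
- compound 2, `CCC(Sc1nc2c(cnn2C)c(=O)n1-c1ccccc1)c1ccccc1`, gives 119 nM
- compound 3, `CC(Sc1nc2c(cnn2C)c(=O)n1-c1ccccc1)c1cccnc1`, gives 95 nM

In this assay compound 3 sits between the other two: the step of a 1.1-fold higher number from compound 1 to compound 3 (0.03 log units; within the scatter) and the step of a 1.3-fold lower number from compound 2 to compound 3 (0.10 log units; within the scatter) are both within the scatter, so the three numbers are not separated.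

Compound 4, `COc1ccccc1C(C)Sc1nc2c(cnn2C)c(=O)n1-c1ccccc1`, differs from compound 3 only in the aryl group: 2-methoxyphenyl in place of pyridin-3-yl on a saturated chain carbon bound to a saturated chain carbon and a sulfur.

Among the compounds with values here, the steps that bear on this change are the aryl swap on the same carbon, a 1.1-fold higher number from compound 1 to compound 3 (0.03 log units; within the scatter), and the change of the whole sulfur substituent, a 1.3-fold higher number from compound 1 to compound 2 (0.13 log units; within the scatter). Neither moved the number beyond the scatter. Compound 4 is therefore expected to stay close to compound 3, with an expected step of a 1.1-fold higher number from compound 3 to compound 4 (0.04 log units; within the scatter), not beyond the scatter in either direction.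

For compound 4 in this assay the estimate is 105 nM, with a range from 40 nM to 280 nM.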

Compound 4, half-maximal inhibitory concentration: 112 nM
Estimate against measurement, compound 4: 1.1-fold (0.03 log units) below; low and high end bracket the measured number.
By their numbers in this assay, from the lowest: compounds 1, 3, 4 and 2 (each within the scatter of the next).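

In this assay, the 2-methoxyphenyl group takes the place of either pyridyl group on the saturated chain carbon without a separable change in the number (pyridin-3-yl: a 1.2-fold higher number from compound 3 to compound 4 (0.07 log units; within the scatter)) (pyridin-2-yl: a 1.3-fold higher number from compound 1 to compound 4 (0.10 log units; within the scatter)). This is the first aryl swap shown at this carbon that removes the ring nitrogen and enlarges the group from 6 to 8 heavy atoms while the methyl-bearing chain carbon stays the same; the earlier carbon-only ring came with a change of the whole sulfur substituent. Nothing on hand explains this flat response.

On these data alone, whether an amine or a carboxylic acid on this aryl ring, or a longer chain on the same carbon, would move the number beyond the scatter remains open. No step shown at this position yet marks a limit to what it accepts.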